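A few compounds are considered here, and "the series" means these few. Any claim that something is new, unique, unknown or untested is made for them only; others in the source may bear on it.

Measured in a functional assay on THP-1 cells (Homo sapiens) for inhibition; on this read-out higher numbers stand for weaker inhibition of growth and lower numbers for stronger inhibition of growth:
- compound 1 `Cc1noc(C)c1-c1ccc2c(c1)c(Cc1ccccc1)cn2CCCCCC(=O)NO`: 15500 nM
- compound 2 `Cc1noc(C)c1-c1ccc2c(c1)c(Cc1ccccc1)cn2CCCCCCC(=O)NO`: 15500 nM

Compound 1, at 15500 nM, stands level with compound 2 at the digits shown, and no other measured compound exists to place it against. The next compound to consider is compound 3 `Cc1ccc(Cc2cn(CCCCCC(=O)NO)c3ccc(-c4c(C)noc4C)cc23)cc1`. Its difference from compound 1 is methyl in place of hydrogen on an aromatic carbon, or benzyl to 4-methylbenzyl.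

Within the data shown here, the only measured step is no change at the digits printed from compound 1 to compound 2 (within the scatter). That step sits on the saturated chain, not on the benzyl group, so it bears on this change only indirectly. Among the measured compounds shown here, no measured pair varies the benzyl group, and the data therefore give neither a size nor a direction for adding the methyl. With nothing pointing either way, no step beyond the scatter is expected in this assay, and the range is kept wide. The expected step is a 1.1-fold lower number from compound 1 to compound 3 (0.04 log units; within the scatter). For compound 3 the estimated value is 14000 nM, with an expected range of 6000 nM to 30000 nM.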

Compound 3, concentration for 50% growth inhibition: 15500 nM
Estimate against measurement, compound 3: 1.1-fold (0.04 log units) below, within the range that was stated.
By their numbers in this assay, from the lowest: compounds 1, 2 and 3 (each within the scatter of the next).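

The benzyl group now has its first measured variation: in this assay, methyl in place of hydrogen on an aromatic carbon, para to a large group, gives no change at the digits printed from compound 1 to compound 3 (within the scatter). The earlier pair varied only the saturated chain, so the series now holds one change on that chain and one on the six-membered aromatic ring of carbon only, and neither step lies beyond the scatter. This single added carbon therefore leaves the growth read-out of compound 3 level with that of compound 1, although one methyl at one carbon does not define how the position responds in general. No available measurement offers an explanation for this result.

On these data alone, whether a carboxylic acid, an amine, a methoxy group or a tert-butyl group at this same carbon would also stay level with compound 1 remains open. Also open, as far as these compounds go, is whether 4-methylbenzyl gives the same result when combined with the (hydroxycarbamoyl)methyl chain end of compound 2.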